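The compounds below may be only part of what the source reports. "The series", "measured", "known", "first", "only" and "open" are said of these compounds alone.

Three compounds share one core and differ only in the group attached to a carbonyl carbon. Compound 1 `CCCC(=O)N1CC2CC(C1)N2` gives 350 nM in an assay on CHO cells for displacement of a labelled ligand from Neuronal acetylcholine receptor; alpha3/alpha6/beta2/beta3 (Homo sapiens), read by scintillation counting; on this read-out lower numbers stand for stronger inhibition and higher numbers for weaker inhibition. Compound 2 `CC(C)C(=O)N1CC2CC(C1)N2` gives 580 nM in this assay, and compound 3 `O=C([C@H]1C[C@@H]1F)N1CC2CC(C1)N2` gives 490 nM in this assay. Compound 3 thus holds the second highest of the three numbers; its nearest neighbour is compound 2 and its furthest is compound 1, and both gaps lie within the scatter. Compound 4 `C[C@H]1C[C@H]1C(=O)N1CC2CC(C1)N2` carries 2-methylcyclopropyl in place of 2-fluorocyclopropyl on a carbonyl carbon. The measured steps on this carbonyl carbon bear directly on that change and all are small: a 1.4-fold higher number from compound 1 to compound 3 (0.15 log units; within the scatter), a 1.2-fold lower number from compound 2 to compound 3 (0.07 log units; within the scatter) and a 1.7-fold higher number from compound 1 to compound 2 (0.22 log units; within the scatter). Every exchange of this group so far has stayed within the scatter, and the new group again has the same number of heavy atoms and the same ring, so nothing beyond the scatter is expected in this assay either. For compound 4 the expected step is a 1.1-fold lower number from compound 3 to compound 4 (0.04 log units; within the scatter), that is, none beyond the scatter. Compound 4 is therefore estimated at 450 nM, with a range from 220 nM to 900 nM.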

Compound 4, inhibition constant: 170 nM
Estimate against measurement, compound 4: 2.6-fold (0.42 log units) above; the whole stated range lies above it.
By their numbers in this assay, from the lowest: compound 4; then compounds 1, 3 and 2 (each within the scatter of the next).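

In this assay, going by these compounds alone, this carbonyl position proves more sensitive than the earlier compounds showed: the change to 2-methylcyclopropyl gives a 2.9-fold lower number from compound 3 to compound 4 (0.46 log units; beyond the scatter) and is the first exchange here to pass beyond the scatter. Compound 4 also separates from the open-chain groups, with a 3.4-fold lower number from compound 2 to compound 4 (0.53 log units; beyond the scatter) and a 2.1-fold lower number from compound 1 to compound 4 (0.31 log units; beyond the scatter) in the same direction, so its number is the lowest of the four, though each step is only modest. Fluorine and carbon are the only difference in atom count between the two cyclopropyl groups, and nothing here explains why that exchange moves the number.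

Going by these compounds, whether a larger group on this carbonyl carbon, such as 2-ethylcyclopropyl or cyclobutyl, would lower the number further remains open. So does the effect of a different arrangement of the two defined stereocentres in 2-methylcyclopropyl.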